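A few compounds are considered here, and "the series" means these few. Any claim that something is new, unique, unknown or untested is made for them only; others in the source may bear on it.

Measured in a functional assay on MCF7 cells (Homo sapiens) for antiproliferative activity, read by MTT assay, with a stated time of 72 h; on this read-out higher numbers stand for weaker inhibition and lower numbers for stronger inhibition:
- compound 1 `COc1cc2c(Nc3ccc(C#N)cc3)ncnc2cc1OCCCN1CCCC1`: 16200 nM
- compound 2 `COc1cc2c(Nc3ccc(C#N)cc3)ncnc2cc1OCCCN1CCC(O)CC1`: > 100000 nM (a limit, not a number)
- compound 3 `COc1cc2c(Nc3ccc(C#N)cc3)ncnc2cc1OCCCN1CCC(CO)CC1`: 35100 nM

Compound 3, at 35100 nM, holds the higher of the two exact numbers. Among the measured compounds shown here, the gap to the only other exact number is a 2.2-fold higher number from compound 1 to compound 3 (0.34 log units; beyond the scatter). Compound 2 is reported only as a limit.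

The next structure is compound 4 `COc1cc2c(Nc3ccc(C#N)cc3)ncnc2cc1OCCCN1CCC(N2CCCCC2)CC1`, with piperidin-1-yl in place of hydroxymethyl on a saturated ring carbon, three ring bonds from the ring nitrogen: piperidin-1-yl in place of hydroxymethyl on a saturated ring carbon.

For the measured compounds named here, the only measured change at this ring carbon is an at least 2.8-fold lower number from compound 2 to compound 3 (0.45 log units; beyond the scatter), where hydroxymethyl replaces hydroxy. That step rests on a limit, so its true size is open. Exchanging the whole amine end gave an at least 6.1-fold higher number from compound 1 to compound 2 (0.79 log units; beyond the scatter), also resting on a limit, and the modest step already noted for compound 3. Going by the values given here, no measured step puts a ring on this carbon, so the direction rests on one precedent: a larger group at this carbon gave a lower number in an at least 2.8-fold lower number from compound 2 to compound 3 (0.45 log units; beyond the scatter).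

A modest move toward a lower number is therefore expected, though a move the other way remains possible. The expected step in this assay is a 1.4-fold lower number from compound 3 to compound 4 (0.15 log units; within the scatter). For compound 4 the estimate is 25000 nM, with an expected range from 7000 nM to 90000 nM.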

Compound 4, half-maximal inhibitory concentration: 19600 nM
Compound 4: the middle estimate sits 1.3-fold (0.11 log units) above what was measured; measured number inside the range.
By their numbers in this assay, from the lowest: compounds 1, 4 and 3 (each within the scatter of the next, the first and the last beyond it). At a limit, above all of these: compound 2.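

In this assay, a whole second ring is accepted on the saturated ring carbon three ring bonds from the ring nitrogen: a 1.8-fold lower number from compound 3 to compound 4 (0.25 log units; within the scatter), so piperidin-1-yl and hydroxymethyl cannot be told apart here, and the hydrogen-bond donor counted for hydroxymethyl can go without a change beyond the scatter. The full amine end behaves the same way, with a 1.2-fold higher number from compound 1 to compound 4 (0.08 log units; within the scatter), so 4-(piperidin-1-yl)piperidin-1-yl and pyrrolidin-1-yl also cannot be told apart. Among the new steps only the one from hydroxy stands out, with an at least 5.1-fold lower number from compound 2 to compound 4 (0.70 log units; beyond the scatter), and the value of compound 2 is a limit, so this step has a bound and no exact size: the limit of > 100000 nM in this assay, at which 1 of the 4 values shown sits.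

Still open, from the compounds shown here alone, is whether a smaller amine such as dimethylamino, or a carboxylic acid, on this ring carbon would stay with compound 3 and compound 4 or move toward compound 2. Also open is what a longer chain between the ring oxygen and the amine end would do, as the chain is the same in every compound shown.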